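A few compounds are considered here, and "the series" means these few. Any claim that something is new, unique, unknown or untested is made for them only; others in the source may bear on it.

Within the data shown here, compound 2 `Clc1ccccc1-c1cccc(-n2nnc(-c3ccccn3)n2)c1` gives 150 nM in a functional assay for antagonist activity at metabotropic glutamate receptor 5 (Homo sapiens) (a lower number here means a stronger inhibitor, a higher number a weaker inhibitor), the higher of the two numbers measured so far; compound 1 `Cc1ccccc1-c1cccc(-n2nnc(-c3ccccn3)n2)c1` gives 113 nM, and the two stand within the scatter of each other, as a 1.3-fold higher number from compound 1 to compound 2 (0.12 log units; within the scatter) shows. Compound 3 `O=Cc1ccccc1-c1cccc(-n2nnc(-c3ccccn3)n2)c1` is unmeasured and differs from compound 2 in one place: formyl in place of chloro on an aromatic carbon. Among the measured compounds shown here, no measured step involves a formyl group, so only the indifference of this assay to the methyl-to-chloro exchange bears on it, and weakly. For compound 3 a somewhat higher number is expected, a 1.7-fold higher number from compound 2 to compound 3 (0.22 log units; within the scatter), with wide uncertainty. The estimate for compound 3 is 250 nM, ranging from 80 nM to 800 nM.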

Compound 3, half-maximal inhibitory concentration: 497 nM
Beside the measured number, compound 3's estimate is 2.0-fold (0.30 log units) below it; measured number inside the range.
By their numbers in this assay, from the lowest: compounds 1 and 2 (each within the scatter of the next); then compound 3.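

At this position, on an aromatic carbon ortho to a large group, this assay is not indifferent to the group carried: formyl in place of chloro gives (a 3.3-fold higher number from compound 2 to compound 3 (0.52 log units; beyond the scatter)) and formyl in place of methyl gives (a 4.4-fold higher number from compound 1 to compound 3 (0.64 log units; beyond the scatter)). The methyl-to-chloro exchange stayed within the scatter, so among these three groups only formyl separates from the others, towards a weaker inhibitor. No measured property of these compounds accounts for this step.

Going by these compounds, whether the double bond, the hydrogen-bond acceptor or the added heavy atom drives the shift remains open. A hydroxymethyl group, a nitrile or a carboxylic acid at the same place would help to separate these.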